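The compounds below may be only part of what the source reports. "The series", "measured", "known", "first", "only" and "open" are said of these compounds alone.

For the measured compounds named here, compound 1 `COC(=O)c1sc2cc(Nc3ccc(OC)cc3)cnc2c1N` is the weaker of the two compounds measured so far: in a functional assay on MCF7 cells (Homo sapiens) for inhibition, read by sulforhodamine B assay, with a stated time of 48 h (on this read-out higher numbers stand for weaker inhibition of growth and lower numbers for stronger inhibition of growth), compound 1 gives 124000 nM, the highest number of the pair. Compound 2 `COC(=O)c1sc2cc(Nc3ccc(OC)cc3OC)cnc2c1N` gives 26300 nM in this assay, and the step of a 4.7-fold lower number from compound 1 to compound 2 (0.67 log units; beyond the scatter) shows that adding a methoxy group can strengthen growth inhibition. Compound 3 `COC(=O)c1sc2cc(Nc3ccc(OC)c(OC)c3)cnc2c1N` carries the same kind of change at a different place: methoxy in place of hydrogen on an aromatic carbon, ortho to a methoxy group and meta to a large group. Going by the values given here, since the only comparable step is that from compound 1 to compound 2, a modest lowering is expected for compound 3, a 2.8-fold lower number from compound 1 to compound 3 (0.44 log units; beyond the scatter), giving an estimate of 45000 nM with a range from 15000 nM to 130000 nM.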

Compound 3, concentration for 50% growth inhibition: 30000 nM
Estimate against measurement, compound 3: 1.5-fold (0.18 log units) above; the measured number falls inside the stated range.
By their numbers in this assay, from the lowest: compounds 2 and 3 (each within the scatter of the next); then compound 1.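

In this assay, a methoxy group placed ortho to a methoxy group and meta to a large group also strengthens growth inhibition, giving a 4.1-fold lower number from compound 1 to compound 3 (0.62 log units; beyond the scatter). The gain seen earlier is therefore not tied to a single place: compound 2 and compound 3 carry the added methoxy at different places, yet lie within the scatter of each other. Nothing available explains this gain. On these data alone, whether a different group at this place, such as an amine or a longer chain, would lower the number as well remains open.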